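The source may hold more compounds than are shown below. What is called first, only, known or untested is meant among the compounds shown, and "the series" means these compounds.

Measured so far:
- compound 1 `N[C@@H](COP(=O)(O)OCCCOC(=O)CCc1ccccc1OCc1cccc(Cc2ccccc2)c1)C(=O)O`, an assay on cells for activation of probable G-protein coupled receptor 34 (Mus musculus), with a stated time of 1 h; a higher number here means a larger maximal response, a lower number a smaller maximal response: 0.077
- compound 2 `N[C@@H](COP(=O)(O)OCCCOC(=O)CCc1ccccc1OCc1cccc(Oc2cccc(Cl)c2)c1)C(=O)O`, this assay: 0.53

Compound 2 stands highest of the two, set apart from compound 1 by a number 0.45 higher from compound 1 to compound 2 (beyond the scatter). Compound 3 `CCc1ccc(Oc2cccc(COc3ccccc3CCC(=O)OCCCOP(=O)(O)OC[C@H](N)C(=O)O)c2)cc1` differs from compound 2 in one place: 4-ethylphenyl in place of 3-chlorophenyl on an oxygen on an aromatic ring. Going by the values given here, no measured step swaps one group for another on this oxygen; the single step from compound 1 to compound 2 replaced a benzyl with the whole 3-chlorophenoxy group, so it does not bear directly on this exchange, and only a small change is expected. For compound 3 the estimated step is a number 0.080 lower from compound 2 to compound 3 (within the scatter), giving an expected value of 0.45, within 0.2 to 0.75.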

Compound 3, intrinsic activity: the largest response reached, as a fraction of the reference agonist's: 0.42
The estimate for compound 3 lay 0.030 above the measured number; the range from low to high includes it.
By their numbers in this assay, from the lowest: compound 1; then compound 3; then compound 2.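

Swapping 3-chlorophenyl for 4-ethylphenyl on this oxygen gives a number 0.11 lower from compound 2 to compound 3 (beyond the scatter) in this assay, so the group's identity matters here, though the effect is smaller than the change from the benzyl. Chlorine is also not required for a response well clear of compound 1, as the ring without it still gives a number 0.34 higher from compound 1 to compound 3 (beyond the scatter). Nothing available explains the difference between these two groups.

As far as these compounds go, it remains open whether the step follows from the group's place on the ring or from ethyl versus chlorine; 4-chlorophenyl or 3-ethylphenyl would separate the two. From the compounds shown here alone, how an amine on this ring would behave is also open.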